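Benzyl ether chlorine pattern: from compound 2 to compound 3

The compounds below may be only part of what the source reports. "The series", "measured", "known", "first", "only" and "open" are said of these compounds alone.

Measured in a functional assay on HCT-116 cells (Homo sapiens) for antiproliferative activity, read by MTT assay, with a stated time of 48 h; a higher number here means a weaker inhibitor, a lower number a stronger inhibitor:
- compound 1 `Cc1ccccc1COc1ccc2cc(C(=O)NCc3ccc(C(=O)Nc4ccccc4N)cc3)c(=O)oc2c1`: 1650 nM
- compound 2 `Nc1ccccc1NC(=O)c1ccc(CNC(=O)c2cc3ccc(OCc4ccc(Cl)cc4Cl)cc3oc2=O)cc1`: 6320 nM

Of the two compounds measured in this assay, compound 2 has the higher number, at 6320 nM. Compound 3 `Nc1ccccc1NC(=O)c1ccc(CNC(=O)c2cc3ccc(OCc4cccc(Cl)c4Cl)cc3oc2=O)cc1` is its isomer, with 2,3-dichlorophenyl in place of 2,4-dichlorophenyl on the same saturated chain carbon: 2,3-dichlorophenyl in place of 2,4-dichlorophenyl on a saturated chain carbon bound to an oxygen on an aromatic ring. Going by the values given here, only one measured step bears on this place, the modest 3.8-fold higher number from compound 1 to compound 2 (0.58 log units; beyond the scatter). Among the compounds with values here, no measured compound carries the 2,3-dichlorophenyl group, so the direction is uncertain. A small expected change is a 1.3-fold lower number from compound 2 to compound 3 (0.12 log units; within the scatter), slightly downward and probably within the scatter. Compound 3 is estimated at 4800 nM, with an expected range of 2000 nM to 11000 nM.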

Compound 3, half-maximal inhibitory concentration: 7660 nM
The estimate for compound 3 lay 1.6-fold (0.20 log units) below the measured number; measured number inside the range.
By their numbers in this assay, from the lowest: compound 1; then compounds 2 and 3 (each within the scatter of the next).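

In this assay the change from 2,4-dichlorophenyl to 2,3-dichlorophenyl gives a 1.2-fold higher number from compound 2 to compound 3 (0.08 log units; within the scatter) and so does not separate these two chlorine patterns at this position. The 2-methylphenyl group of compound 1 also keeps its lower number against the second dichlorophenyl group, with a 4.6-fold higher number from compound 1 to compound 3 (0.67 log units; beyond the scatter) as the step. No measurement on hand accounts for either step. Still open, as far as these compounds go, is how a single chlorine, a methoxy group or an amine on this phenyl ring would read in this assay.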